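Swapping a hydroxymethyl for a vinyl on the amide carbonyl

This account rests on a few compounds, and the source may have more. Where it says the series, first, only, none or still open, it means among the compounds named here.

Three compounds share a core in which an amide-type nitrogen carries a benzyl group bearing a methoxy and a hydroxy, and an aryl ring with three methoxy groups; they differ only in what sits on the carbonyl carbon. Compound 1 `C/C=C/C=C/C(=O)N(Cc1ccc(OC)c(O)c1)c1cc(OC)c(OC)c(OC)c1` carries a penta-1,3-dien-1-yl chain and gives 180 nM in a functional assay on KYSE-450 cells (Homo sapiens) for inhibition, read by MTT assay, with a stated time of 48 h; on this read-out lower numbers stand for stronger inhibition and higher numbers for weaker inhibition. Compound 2 `CCC/C=C/C(=O)N(Cc1ccc(OC)c(O)c1)c1cc(OC)c(OC)c(OC)c1` carries a pent-1-en-1-yl chain and in this assay gives 57 nM. Compound 3 `COc1ccc(CN(C(=O)CO)c2cc(OC)c(OC)c(OC)c2)cc1O` carries a hydroxymethyl and in this assay gives 370 nM, the highest of the three numbers, with the steps to both others beyond the scatter.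

Compound 4 `C=CC(=O)N(Cc1ccc(OC)c(O)c1)c1cc(OC)c(OC)c(OC)c1` is not yet measured. It differs from compound 3 by vinyl in place of hydroxymethyl on a carbonyl carbon, so a short double-bonded chain replaces the hydroxymethyl.

For the measured compounds named here, the steps that bear on this are a 2.1-fold higher number from compound 1 to compound 3 (0.31 log units; beyond the scatter) and a 6.5-fold higher number from compound 2 to compound 3 (0.81 log units; beyond the scatter): in both, replacing an unsaturated chain on the carbonyl carbon with hydroxymethyl raised the number. Going the other way with the shortest such chain should therefore lower it, though vinyl is shorter than either chain already measured, so the size is uncertain. A step of a 3.1-fold lower number from compound 3 to compound 4 (0.49 log units; beyond the scatter) is expected. Compound 4 is estimated to give 120 nM in this assay, within 50 nM to 300 nM.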

Compound 4, half-maximal inhibitory concentration: 160 nM
Compound 4: middle estimate off by 1.3-fold (0.12 log units), on the low side; the range from low to high includes it.
By their numbers in this assay, from the lowest: compound 2; then compounds 4 and 1 (each within the scatter of the next); then compound 3.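

The shortest unsaturated chain also improves on hydroxymethyl, with vinyl on the carbonyl carbon giving a 2.3-fold lower number from compound 3 to compound 4 (0.36 log units; beyond the scatter) in this assay; since both groups have 2 heavy atoms, the number at this position can move with no change in that count. Chain length alone does not set the order of the numbers, as lengthening the vinyl to pent-1-en-1-yl is the reverse of a 2.8-fold higher number from compound 2 to compound 4 (0.45 log units; beyond the scatter) and so brings a real gain, whereas the step of a 1.1-fold lower number from compound 1 to compound 4 (0.05 log units; within the scatter) shows that vinyl and penta-1,3-dien-1-yl cannot be told apart in this assay. Nothing measured here accounts for why these groups differ.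

An ethyl on the carbonyl carbon would show whether the double bond of vinyl matters at this short length, and a pentyl chain would do the same for the longer chains. On these data alone, it also remains open how an aminomethyl group or a carboxylic acid at this position would compare with hydroxymethyl and with the unsaturated chains.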